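The source may hold more compounds than are shown below. What is called first, only, known or untested is meant among the compounds shown, and "the series" means these compounds.

Measured so far:
compound 1 `O=C1Nc2ccc(Br)cc2/C1=N/NC(=S)N/N=C/c1ccc(-c2ccccc2)cc1` — 3250 nM
compound 2 `O=C1Nc2ccc(Br)cc2/C1=N/NC(=S)N/N=C/c1ccc(Br)cc1` — 4680 nM

In a functional assay on HeLa cells (Homo sapiens) for inhibition, read by MTT assay (a higher number here means a weaker inhibitor, a lower number a stronger inhibitor), compound 1 gives 3250 nM and compound 2 gives 4680 nM; the step of a 1.4-fold higher number from compound 1 to compound 2 (0.16 log units; within the scatter) lies within the scatter, so the two stand level. Compound 3 `Cc1ccc2c(c1)/C(=N/NC(=S)N/N=C/c1ccc(-c3ccccc3)cc1)C(=O)N2` differs from compound 1 by methyl in place of bromo on an aromatic carbon. Going by the values given here, no measured step touches this position on the core; the only step known, bromo in place of phenyl on the other aryl, was within the scatter. With nothing pointing either way, the step of a 1.0-fold higher number from compound 1 to compound 3 (0.01 log units; within the scatter) is expected to stay within the scatter. The estimate for compound 3 in this assay is 3300 nM, range 1200 nM to 9000 nM.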

Compound 3, half-maximal inhibitory concentration: > 50000 nM
Compound 3 ended at the assay's limit (the forecaster's own chance of this, stated with the estimate: 5%); at least 15-fold (1.18 log units) between middle value and limit.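

In this assay, methyl in place of bromo on this aromatic carbon of the core gives an at least 15-fold higher number from compound 1 to compound 3 (1.18 log units; beyond the scatter). This position therefore tolerates change far less than the other aryl position, where a 1.4-fold higher number from compound 1 to compound 2 (0.16 log units; within the scatter) showed no separation. The value of compound 3 is a limit of the assay and not a number, so the full size of the step stays unknown: the limit of > 50000 nM in this assay, at which 1 of the 3 values shown sits.

As far as these compounds go, it remains open whether the loss is specific to methyl or extends to other replacements for bromo. A chloro, methoxy or amine group on this carbon would separate these cases.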